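This account rests on a few compounds, and the source may have more. Where it says the series, first, only, none or still open, it means among the compounds named here.

Working notes on the series. Compound 1 `COc1ccc(/C=C/C(=O)c2ccc(OC)c3c2OC(C)(C)C=C3)c(F)c1` in a functional assay on HCT-116 cells (Homo sapiens) for antiproliferative activity, read by MTT assay, with a stated time of 24 h (on this read-out lower numbers stand for stronger inhibition and higher numbers for weaker inhibition), gives > 10000 nM, which is a limit of the assay and not a number. Compound 2 `COc1ccc(C(=O)/C=C/c2ccc(N(c3ccccc3)c3ccccc3)cc2)c2c1C=CC(C)(C)O2` in this assay gives > 10000 nM, again a limit. Compound 3 `COc1ccc(C(=O)/C=C/c2cccc3ccccc23)c2c1C=CC(C)(C)O2` in this assay gives > 10000 nM, also a limit. Compound 1 therefore stands together with the other two at the limit of > 10000 nM in this assay, at which 3 of the 3 values shown sit, and nothing among the three sets it apart. Compound 4 `COc1ccc(C(=O)/C=C/c2ccccc2Cl)c2c1C=CC(C)(C)O2` is not yet measured; relative to compound 1 the change is 2-chlorophenyl in place of 2-fluoro-4-methoxyphenyl on a double-bonded chain carbon bound to a double-bonded chain carbon. Within the data shown here, no step between measured compounds exists in this set, so no size of effect can be drawn from it. Compound 4 is expected to remain near the same limit, the estimated step that the limit leaves unreadable from compound 1 to compound 4 staying within the scatter. Compound 4 is estimated at 20000 nM, between 5000 nM and 80000 nM.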

Compound 4, half-maximal inhibitory concentration: > 10000 nM
Compound 4: only a limit was reported (the forecaster's own chance of this, stated with the estimate: 75%); the middle value does not contradict the limit.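

Compound 1 and compound 4 both give a limit and not a number, so no step between them can be read: the limit of > 10000 nM in this assay, at which 4 of the 4 values shown sit.

The compounds shown leave open whether any change on the shared core gives a readable value in this assay.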